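The source may hold more compounds than are shown below. What is called first, only, known or untested is meant among the compounds shown, and "the series" means these compounds.

Compound 1 `Cc1ccc(CNC(=O)c2cccc(C(C)Oc3ccnc(Nc4cnn(C5CCN(C)CC5)c4)c3)c2)cc1` — 8900 nM
Compound 2 `Cc1ccc(CNC(=O)c2cccc(C(C)Oc3ccnc(Nc4cnn(C)c4)c3)c2)cc1` — 7700 nM
Compound 3 `Cc1ccc(CNC(=O)c2cccc(C(C)Oc3ccnc(Nc4cn(C)nc4C)c3)c2)cc1` — 13400 nM

Of the compounds shown here, three sharing one core have been measured in a functional assay on NCI-H3122 cells (Homo sapiens) for antiproliferative activity, read by MTT assay, with a stated time of 48 h; a higher number here means a weaker inhibitor, a lower number a stronger inhibitor. Compound 3 gives the highest of the three numbers, yet its nearest neighbour is compound 1 at a 1.5-fold higher number from compound 1 to compound 3 (0.18 log units; within the scatter), and its furthest is compound 2 at a 1.7-fold higher number from compound 2 to compound 3 (0.24 log units; within the scatter), so the three values are not separated beyond the usual scatter. The step from compound 1 to compound 2, a 1.2-fold lower number from compound 1 to compound 2 (0.06 log units; within the scatter), likewise changed little.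

Compound 4 `Cc1ccc(CNC(=O)c2cccc(C(C)Oc3ccnc(NN4CCOCC4)c3)c2)cc1` is not yet measured. It differs from compound 3 in one place: morpholin-4-yl in place of 1,3-dimethyl-1H-pyrazol-4-yl on a nitrogen on an aromatic ring. Within the data shown here, none of the measured steps touches this change; all of them altered the substituents of the same five-membered aromatic ring, and all stayed within the scatter. That gives no direct guide, only the observation that this part of the molecule has so far tolerated change without a shift beyond the scatter.

Compound 4 is therefore expected to give roughly 15000 nM in this assay, between 5000 nM and 50000 nM. Among the measured compounds shown here, the expected step is a 1.1-fold higher number from compound 3 to compound 4 (0.05 log units; within the scatter), with the wide range reflecting that no measured step bears on it.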

Compound 4, half-maximal inhibitory concentration: > 100000 nM
Compound 4: a limit, no number (the forecaster's own chance of this, stated with the estimate: 25%); middle value at least 6.6-fold (0.82 log units) away from the limit.
By their numbers in this assay, from the lowest: compounds 2, 1 and 3 (each within the scatter of the next). At a limit, above all of these: compound 4.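

In this assay compound 4 carries a limit and not a number: the limit of > 100000 nM in this assay, at which 1 of the 4 values shown sits.

Earlier changes to the substituents of the five-membered aromatic ring stayed within the scatter, but replacing that ring with morpholin-4-yl gives an at least 7.4-fold higher number from compound 3 to compound 4 (0.87 log units; beyond the scatter), and the same exchange gives an at least 12-fold higher number from compound 2 to compound 4 (1.11 log units; beyond the scatter) and an at least 11-fold higher number from compound 1 to compound 4 (1.05 log units; beyond the scatter). So this nitrogen on an aromatic ring accepts different pyrazole groups among the compounds shown, yet the six-membered non-aromatic morpholin-4-yl ring is not an equal replacement for them.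

As far as these compounds go, it remains open whether another aromatic ring, such as phenyl or thiazole, would give numbers like those of the pyrazoles. Also open, from the compounds shown here alone, is whether a piperidin-1-yl ring, with carbon in place of the morpholine oxygen, would behave like morpholin-4-yl.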